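Working notes: from compound 1 to compound 4

The source may report more compounds than this note shows. Statements on the series, on what has been measured and on what is new or still open speak of the compounds shown alone.

- compound 1 `COc1ccc(-c2nc3c(c(-c4ccccc4)nn3-c3ccccc3)c(-c3ccc(N4CCCCC4)cc3)c2C#N)cc1` gives 2760 nM in a functional assay on MCF7 cells (Homo sapiens) for inhibition, read by MTT assay, with a stated time of 48 h; on this read-out lower numbers stand for stronger inhibition and higher numbers for weaker inhibition
- compound 2 `N#Cc1c(-c2ccccc2)nc2c(c(-c3ccccc3)nn2-c2ccccc2)c1-c1ccc(N2CCCCC2)cc1` gives 27000 nM in this assay
- compound 3 `COc1ccc(-c2ccnc3c2c(-c2ccccc2)nn3-c2ccccc2)cc1` gives 28700 nM in this assay

Compound 1 holds the lowest of the three numbers, and both of the others stand clearly higher. The next structure is compound 4 `COc1ccc(-c2nc3c(c(-c4ccccc4)nn3-c3ccccc3)c(-c3ccc(N4CCN(C)CC4)cc3)c2C#N)cc1`, which has 4-methylpiperazin-1-yl in place of piperidin-1-yl on an aromatic carbon, para to a large group: 4-methylpiperazin-1-yl in place of piperidin-1-yl on an aromatic carbon.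

Within the data shown here, the only measured step between compounds that differ in one place is a 9.8-fold higher number from compound 1 to compound 2 (0.99 log units; beyond the scatter) on hydrogen replacing methoxy on an aromatic carbon. That step concerns another group, so it gives only a rough idea of how far a single change can move the number in this series. Compound 3 differs from compound 1 in more than one place and isolates no single change. Among the measured compounds shown here, no measured pair varies the piperidin-1-yl group, so the data give no direction for this change.

No step beyond the scatter is therefore expected in this assay, and the estimate is a 1.0-fold lower number from compound 1 to compound 4 (0.01 log units; within the scatter) with wide uncertainty either way. Compound 4 is expected at 2700 nM with 800 nM to 9000 nM as the estimated range.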

Compound 4, half-maximal inhibitory concentration: 2650 nM
Compound 4: middle estimate off by 1.0-fold (0.01 log units), on the high side, within the range that was stated.
By their numbers in this assay, from the lowest: compounds 4 and 1 (each within the scatter of the next); then compounds 2 and 3 (each within the scatter of the next).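

In this assay, 4-methylpiperazin-1-yl in place of piperidin-1-yl on an aromatic carbon, para to a large group, gives a 1.0-fold lower number from compound 1 to compound 4 (0.02 log units; within the scatter); the two compounds cannot be told apart on this read-out, even though the entering ring carries a second nitrogen and a methyl group. Among these compounds, this is the only measured pair that varies this group, and it sets a scatter-level step here against a 9.8-fold higher number from compound 1 to compound 2 (0.99 log units; beyond the scatter), the step for hydrogen in place of methoxy, which lies beyond the scatter. The series therefore has one place where a single change moves the number and one where this particular exchange of six-membered rings does not, and no measurement on hand bears on why the two values agree.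

The compounds shown leave open whether this position stays as insensitive with a morpholin-4-yl group, an open-chain dimethylamino group or a carboxylic acid on the same aromatic carbon. They also leave open whether the same ring exchange would give a similar step on the background of compound 2, which has hydrogen in place of methoxy.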